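Indole-like dithiocarbamate series: removal of the ring chlorine

A few compounds are considered here, and "the series" means these few. Any claim that something is new, unique, unknown or untested is made for them only; others in the source may bear on it.

Measured so far:
compound 1, `O=C(CSCc1ccccc1)Nc1c(-c2ccccc2)[nH]c2ccccc12` — 33000 nM
compound 2, `OC1CCCN(C(=S)Sc2c(-c3ccc(Br)cc3)[nH]c3ccc(Cl)cc23)C1` — 31000 nM

In a functional assay on Hs 683 cells (Homo sapiens) for inhibition, read by MTT assay, with a stated time of 72 h (on this read-out lower numbers stand for stronger inhibition of growth and higher numbers for weaker inhibition of growth), compound 1 gives 33000 nM and compound 2 gives 31000 nM. Compound 2 carries the lower of the two numbers, but the gap to compound 1 lies within the usual scatter of this assay, so the two compounds cannot be told apart on these data. Going by the values given here, no pair of measured compounds differs in one place, so no measured step is available for the series.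

Compound 3, `OC1CCCN(C(=S)Sc2c(-c3ccc(Br)cc3)[nH]c3ccccc23)C1`, has not yet been measured. It is derived from compound 2 by the change (hydrogen in place of chloro on an aromatic carbon). The core of compound 2 is otherwise kept. Among the compounds with values here, since no measured step in this assay informs the change, the expectation rests on the unchanged remainder of compound 2 and on its value 31000 nM. For the step of a 1.4-fold higher number from compound 2 to compound 3 (0.13 log units; within the scatter) a small shift toward weaker inhibition of growth is expected, of a size that may not exceed the scatter. Compound 3 is therefore estimated at 42000 nM, with a range from 15000 nM to 110000 nM.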

Compound 3, concentration for 50% growth inhibition: 24000 nM
Compound 3: middle estimate off by 1.8-fold (0.24 log units), on the high side; measured number inside the range.
By their numbers in this assay, from the lowest: compounds 3, 2 and 1 (each within the scatter of the next).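

In this assay, the series now has its first measured step, a 1.3-fold lower number from compound 2 to compound 3 (0.11 log units; within the scatter), and it lies within the scatter. On this aromatic carbon, meta to a fused ring and para to a fused ring, the chloro can therefore be exchanged for hydrogen with no difference that these data can resolve, and compound 3, which lacks the chlorine, still gives 24000 nM, so the chloro is not needed for a number of this size in this assay. No measurement at hand bears on why this exchange leaves the number within the scatter.

Still open, going by these compounds, is whether any group on this same carbon can move the number beyond the scatter, since hydrogen and chloro are the only two substituents compared here; a methoxy group, a nitrile or an amine would test this. Also open, on these data alone, is whether the bromo on the other aromatic ring or the hydroxyl group of the dithiocarbamate amine matters more than the chloro does, for example with hydrogen in place of the bromo or a carboxylic acid in place of the hydroxyl group.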